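The compounds below may be only part of what the source reports. "The series", "measured", "known", "first", "only" and "open" are said of these compounds alone.

In a functional assay on the whole organism for antagonist activity, with Mus musculus as the target, in the maximal electroshock model (on this read-out higher numbers stand for an effect only at larger amounts of compound and lower numbers for an effect already at smaller amounts), compound 1 `COc1ccc(-c2nnc([S+](C)[O-])n2C)cc1` gives > 100 mg/kg, which is a limit of the assay and not a number. Compound 2 `COc1ccc(-c2nnc(S(C)(=O)=O)n2C)cc1` in this assay gives > 200 mg/kg, again a limit of the assay. The change between them, (a group of 4 heavy atoms (1 carbon, 2 oxygen, 1 sulfur; no ring) in place of a group of 3 heavy atoms (1 carbon, 1 oxygen, 1 sulfur; no ring), on an aromatic carbon), gave a step that the two limits leave unreadable from compound 1 to compound 2; the two limits, recorded as the limit of > 100 mg/kg in this assay, at which 1 of the 3 values shown sits, and (the limit of > 200 mg/kg in this assay, at which 2 of the 3 values shown sit), leave its size unreadable. Compound 3 `Cn1nc([S+](C)[O-])nc1-c1ccccc1` in this assay gives > 200 mg/kg, also a limit of the assay. How the core of compound 3 differs from that of compound 1 is not broken down here.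

Compound 4 `Cn1nc(S(C)(=O)=O)nc1-c1ccccc1` is not yet measured. It differs from compound 3 by a group of 4 heavy atoms (1 carbon, 2 oxygen, 1 sulfur; no ring) in place of a group of 3 heavy atoms (1 carbon, 1 oxygen, 1 sulfur; no ring), on an aromatic carbon, the same kind of change as that from compound 1 to compound 2, though the place is not the same in every word: in compound 1 the group sits next to the ring atom that bears a methyl group, whereas in compound 3 it sits two ring bonds from the ring atom that bears a methyl group. Because compound 3 already stands at the limit of > 200 mg/kg in this assay, at which 2 of the 3 values shown sit, and compound 2 likewise sits at the limit of > 200 mg/kg in this assay, at which 2 of the 3 values shown sit, the step from compound 3 to compound 4 is expected to be a step that the limit leaves unreadable from compound 3 to compound 4, most likely unreadable in this assay. Compound 4 in this assay is expected to give about 300 mg/kg, within 150 mg/kg to 700 mg/kg.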

Compound 4, dose for half-maximal effect: > 200 mg/kg
Compound 4 ended at the assay's limit (the forecaster's own chance of this, stated with the estimate: 85%); the middle value does not contradict the limit.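

In this assay compound 4 gives > 200 mg/kg, which is a limit of the assay and not a number. Among these compounds, compound 3 also stands at a limit, and no step from compound 3 to compound 4 can be read. The compounds shown leave open whether methylsulfonyl in this place changes the effect at all: none of the four gives a number.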